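Swapping the amide-borne aryl group: from benzamide to indazole

The source may hold more compounds than are shown below. What is called first, only, known or untested is meant among the compounds shown, and "the series" means these compounds.

Measured compounds:
compound 1 `COC(=O)c1ccc(N(Cc2cnc(C3CCCCC3)cn2)C(=O)[C@H]2CCN2S(=O)(=O)c2c(F)c(F)c(F)c(F)c2F)cc1O`: 1600 nM
compound 2 `NC(=O)c1ccc(N(Cc2ccc(C3CCCCC3)cn2)C(=O)[C@H]2CCN2S(=O)(=O)c2c(F)c(F)c(F)c(F)c2F)c(F)c1`: "not determined" (no result reported)
compound 3 `O=C(NO)c1ccc(N(Cc2cnc(C3CCCCC3)cn2)C(=O)[C@H]2CCN2S(=O)(=O)c2c(F)c(F)c(F)c(F)c2F)cc1O`: 5200 nM

In a functional assay on MDA-MB-231 cells (Homo sapiens) for antiproliferative activity, with a stated time of 72 h (on this read-out lower numbers stand for an effect already at smaller amounts and higher numbers for an effect only at larger amounts of compound), compound 1 gives 1600 nM and compound 3 gives 5200 nM. For the measured compounds named here, the only single-point step, a 3.3-fold higher number from compound 1 to compound 3 (0.51 log units; beyond the scatter), alters the group on the carbonyl carbon, not the group on the amide-type nitrogen. Compound 2 has no number in this assay, so it cannot be placed among the others. Compound 4 `O=C([C@H]1CCN1S(=O)(=O)c1c(F)c(F)c(F)c(F)c1F)N(Cc1ccc(C2CCCCC2)cn1)c1cc2[nH]ncc2cc1F` differs from compound 2 in one place: 5-fluoro-1H-indazol-6-yl in place of 4-carbamoyl-2-fluorophenyl on an amide-type nitrogen. Going by the values given here, no measured step touches this position, so neither size nor direction of the change in this assay can be read from the data, and the whole measured span must serve as a guide. Compound 4 is expected to give roughly 2500 nM, estimated between 300 nM and 20000 nM.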

Compound 4, half-maximal effective concentration: 2300 nM
The estimate for compound 4 lay 1.1-fold (0.04 log units) above the measured number; the measured number falls inside the stated range.
By their numbers in this assay, from the lowest: compounds 1 and 4 (each within the scatter of the next); then compound 3.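

For the compounds shown here, compound 2 has no number, so compound 4, at 2300 nM, gives no new step to read. The effect of exchanging 4-carbamoyl-2-fluorophenyl for 5-fluoro-1H-indazol-6-yl stays open, and no evidence here speaks to a cause.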